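This account rests on a few compounds, and the source may have more. Where it says the series, first, only, none or still open, it means among the compounds named here.

Compound 1 `C1=C(CS/C(=N\C2CCCC2)NC2CCCC2)N2CCN=C2S1` and compound 2 `C1=C(CS/C(=N\C2CCCCCC2)NC2CCCCCC2)N2CCN=C2S1` share one core and differ only in the rings attached to the two nitrogens. Going by the values given here, in a functional assay on CCRF-CEM cells for inhibition of C-X-C chemokine receptor type 4 (Homo sapiens), read by calcium flux (a lower number here means a stronger inhibitor, a higher number a weaker inhibitor), compound 1 gives 493 nM, the higher of the two numbers known. Compound 2 gives 3.1 nM in this assay, a gap far beyond the usual scatter. Compound 3 `C1=C(CS/C(=N\C2CCCCC2)NC2CCCC2)N2CCN=C2S1` carries cyclohexyl in place of cyclopentyl on a double-bonded nitrogen. Among the compounds with values here, no measured step of exactly this kind exists, but compound 2 with larger rings on both nitrogens reaches 3.1 nM, so a downward step for compound 3 is expected, smaller than that whole gap. The number for compound 3 is estimated at 110 nM, within 30 nM to 350 nM. The expected step from compound 1 to compound 3 is a 4.5-fold lower number from compound 1 to compound 3 (0.65 log units; beyond the scatter).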

Compound 3, half-maximal inhibitory concentration: 173 nM
For compound 3 the middle estimate is 1.6-fold (0.20 log units) below the measured one; measured number inside the range.
By their numbers in this assay, from the lowest: compound 2; then compound 3; then compound 1.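

Compound 3 shows that changing the ring on a double-bonded nitrogen alone, with cyclopentyl kept on the other nitrogen, already moves the result in this assay: a 2.8-fold lower number from compound 1 to compound 3 (0.45 log units; beyond the scatter). The earlier pair changed both rings at once, so it could not show what one ring contributes. No supporting measurement explains this step.

The same swap on the other nitrogen has no result among these compounds, so the two nitrogens cannot yet be compared. Going by these compounds, whether a phenyl ring or an open hexyl chain would work on the double-bonded nitrogen also remains open.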